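This account rests on a few compounds, and the source may have more. Where it says the series, first, only, none or still open, it means among the compounds named here.

Measured compounds:
- compound 1, `O=CCN1N=C(c2ccc3ccccc3c2)CC1c1ccccc1[N+](=O)[O-]`: 3480 nM
- compound 2, `COc1ccc(C2CC(c3ccc4ccccc4c3)=NN2CC=O)c(OC)c1OC`: 580 nM
- compound 3, `COc1ccc(C2CC(c3ccc4ccccc4c3)=NN2CC=O)cc1OC`: 2450 nM

All three were tested in a functional assay on OVCAR cells (Homo sapiens) for cytotoxicity, read by sulforhodamine B assay, with a stated time of 48 h; a higher number here means a weaker inhibitor, a lower number a stronger inhibitor. Compound 3 sits second highest of the three numbers: its nearest neighbour is compound 1, whose number is within the usual scatter of it, while compound 2 lies clearly lower. The one single-point step among these, from compound 2 to compound 3, is a 4.2-fold higher number from compound 2 to compound 3 (0.63 log units; beyond the scatter), which comes from replacing a methoxy group with hydrogen on an aromatic carbon.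

Compound 4, `COc1ccc(C2CC(c3ccc4ccccc4c3)=NN2CC=O)cc1`, differs from compound 3 by hydrogen in place of methoxy on an aromatic carbon. Among the measured compounds shown here, that is the same kind of change as the one step already measured, and that step made the number larger. A step of similar direction is therefore expected, though a single example gives only a rough guide to its size. This points to an expected step of a 2.4-fold higher number from compound 3 to compound 4 (0.39 log units; beyond the scatter). Compound 4 is accordingly estimated at 6000 nM, with a range from 2500 nM to 15000 nM.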

Compound 4, half-maximal inhibitory concentration: 5790 nM
The estimate for compound 4 lay 1.0-fold (0.02 log units) above the measured number, and the stated range covers the measured number.
By their numbers in this assay, from the lowest: compound 2; then compounds 3, 1 and 4 (each within the scatter of the next, the first and the last beyond it).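

Removing the methoxy that sits ortho to a methoxy group and meta to a large group gives a 2.4-fold higher number from compound 3 to compound 4 (0.37 log units; beyond the scatter), so this position also responds to the change, and the direction matches the earlier 4.2-fold higher number from compound 2 to compound 3 (0.63 log units; beyond the scatter). The same replacement now has two examples on this ring, and both move the number the same way, though neither shows what a third example would do. Exchanging 2-nitrophenyl for 4-methoxyphenyl on the saturated ring carbon gives a 1.7-fold higher number from compound 1 to compound 4 (0.22 log units; within the scatter), which is within the scatter, so these two compounds cannot be told apart, and nothing available explains why any of these numbers shift.

As far as these compounds go, it remains open whether a hydroxyl group or a fluorine atom at this position would behave like hydrogen or like methoxy. Also open, from the compounds shown here alone, is how a phenyl ring carrying no substituent at all would compare.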